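The compounds below may be only part of what the source reports. "The series", "measured", "known", "first", "only" and "open" are said of these compounds alone.

For the measured compounds named here, compound 2 `COc1ccc(/C=C\C(=O)O)c(OCc2cn(-c3ccc(C#N)cc3)nn2)c1CC=C(C)C` gives the higher of the two numbers so far in a functional assay on COLO 205 cells (Homo sapiens) for cytotoxicity, read by MTT assay, with a stated time of 24 h (on this read-out lower numbers stand for stronger inhibition and higher numbers for weaker inhibition), at 32000 nM, while compound 1 `COc1ccc(/C=C\C(=O)O)c(OCc2cn(-c3ccccc3F)nn2)c1CC=C(C)C` gives 14500 nM. Compound 3 `COc1ccc(/C=C\C(=O)O)c(OCc2cn(-c3nc4ccccc4s3)nn2)c1CC=C(C)C` differs from compound 2 by 1,3-benzothiazol-2-yl in place of 4-cyanophenyl on an aromatic nitrogen. Going by the values given here, the only measured step on the same aromatic nitrogen, a 2.2-fold higher number from compound 1 to compound 2 (0.34 log units; beyond the scatter), concerns a different exchange, so it gives no clear direction for this one and only suggests that such changes stay modest. For compound 3 the expected step is a 1.6-fold lower number from compound 2 to compound 3 (0.20 log units; within the scatter), small and uncertain in direction. Compound 3 is therefore estimated at 20000 nM, within a range from 6000 nM to 60000 nM.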

Compound 3, half-maximal inhibitory concentration: 20200 nM
Estimate against measurement, compound 3: 1.0-fold (0.00 log units) below; low and high end bracket the measured number.
By their numbers in this assay, from the lowest: compounds 1, 3 and 2 (each within the scatter of the next, the first and the last beyond it).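

In this assay, a group with a five-membered and a six-membered aromatic ring, 1,3-benzothiazol-2-yl, can stand on this aromatic nitrogen with no change beyond the scatter against either earlier group (a 1.6-fold lower number from compound 2 to compound 3 (0.20 log units; within the scatter); a 1.4-fold higher number from compound 1 to compound 3 (0.14 log units; within the scatter)). Compound 3 therefore cannot be separated from compound 1 or compound 2, although those two differ beyond the scatter. Nothing available explains this result. Still open, as far as these compounds go, is whether a non-aromatic group here, such as a longer alkyl chain or an amine-bearing chain, would shift the number beyond the scatter.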